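Changing a Side Chain on an Oxygen: Compound 3

A few compounds are considered here, and "the series" means these few. Any claim that something is new, unique, unknown or untested is made for them only; others in the source may bear on it.

Measured so far in a functional assay on a cell-free system (plasma, Oryctolagus cuniculus) for inhibition, with stated times of 5 min, 1 min and 6 min; a higher number here means a weaker inhibitor, a lower number a stronger inhibitor

Compound 1 `CCOC(=O)c1c(C)nc(-c2cccc(C#N)c2)n1OC(C)C` gives 6740 nM

Compound 2 `C=CCOn1c(-c2cccc(C#N)c2)nc(C)c1C(=O)OCC` gives 5860 nM

Compound 2 (5860 nM) stands level with compound 1, because the gap between them lies within the scatter (a 1.2-fold lower number from compound 1 to compound 2 (0.06 log units; within the scatter)). Neither compound ranks ahead of the other.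

The next compound to be tested is compound 3 (`CCOCCOn1c(-c2cccc(C#N)c2)nc(C)c1C(=O)OCC`). It keeps the shared core of compound 2 but has ethoxymethyl in place of vinyl on a saturated chain carbon bound to an oxygen on an aromatic ring. Read one bond further out, this is allyl to 2-ethoxyethyl.

Within the data shown here, only one measured step bears on this chain, the swap of isopropyl for allyl on the same oxygen, and it was small (a 1.2-fold lower number from compound 1 to compound 2 (0.06 log units; within the scatter)). On that basis, no step beyond the scatter is expected in this assay, and no direction can be favoured. This is thin evidence, since the entering group carries an oxygen that neither measured chain has, so the range is kept wide.

The expected step is small (a 1.0-fold higher number from compound 2 to compound 3 (0.01 log units; within the scatter)).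

For compound 3 the estimate is 6000 nM (expected range 2500 nM to 14000 nM).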

Compound 3, half-maximal inhibitory concentration: 6250 nM
Beside the measured number, compound 3's estimate is 1.0-fold (0.02 log units) below it; the range from low to high includes it.
By their numbers in this assay, from the lowest: compounds 2, 3 and 1 (each within the scatter of the next).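

In this assay, swapping the allyl chain on the ring oxygen for the larger 2-ethoxyethyl chain, which brings in an oxygen and a hydrogen-bond acceptor, gives no change that can be told apart from scatter (a 1.1-fold higher number from compound 2 to compound 3 (0.03 log units; within the scatter)). The comparison with the branched isopropyl chain reads the same way (a 1.1-fold lower number from compound 1 to compound 3 (0.03 log units; within the scatter)), so three chains that differ in size, in shape and in containing an ether oxygen all stand level at this position. Compound 3 therefore extends what compounds 1 and 2 could show: a chain with a hydrogen-bond acceptor fits the same flat picture as the two chains without one, and no measurement shown here offers an explanation for this.

What the three compounds leave open is whether this position stays as unresponsive with a different kind of group on the oxygen, such as a chain ending in an amine or a carboxylic acid, a much longer chain, or a benzyl group. They also say nothing about changes elsewhere on the shared core, such as replacing the nitrile or the ethyl ester.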